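Bromo removal in an imidazolylbutoxy benzamide series

A few compounds are considered here, and "the series" means these few. Any claim that something is new, unique, unknown or untested is made for them only; others in the source may bear on it.

Three compounds of this series have been run in a functional assay on K562 cells (Homo sapiens) for cytotoxicity, read by XTT assay, with a stated time of 24 h; a lower number here means a stronger inhibitor, a higher number a weaker inhibitor. Compound 1 `Cc1ccc(NC(=O)c2ccc(OCCCCn3ccnc3)c(Br)c2)cc1Nc1nccc(-c2cccnc2)n1` gives 12000 nM, the lowest of the three numbers. Compound 2 `COc1ccc(C(=O)Nc2ccc(C)c(Nc3nccc(-c4cccnc4)n3)c2)c(OCCCCn2ccnc2)c1` gives 58900 nM in this assay, and compound 3 `Cc1ccc(NC(=O)c2cc(I)ccc2OCCCCn2ccnc2)cc1Nc1nccc(-c2cccnc2)n1` gives 66500 nM; both gaps to compound 1 lie beyond the usual scatter, so compound 1 is the strongest inhibitor of the three, although all three numbers are high.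

Compound 4 `Cc1ccc(NC(=O)c2ccc(OCCCCn3ccnc3)cc2)cc1Nc1nccc(-c2cccnc2)n1` is the next to be measured. It differs from compound 1 in one place: hydrogen in place of bromo on an aromatic carbon. For the measured compounds named here, no pair of measured compounds differs in this single place, so no measured step guides the expectation; compounds 2 and 3 differ from compound 1 in several places at once.

The change removes only one heavy atom, and the series sits at weak potency overall, so a small step is expected, most likely toward a somewhat higher number. Compound 4 is therefore estimated at 20000 nM, with a range from 8000 nM to 50000 nM. The estimated step is a 1.7-fold higher number from compound 1 to compound 4 (0.22 log units; within the scatter), expected to sit near the edge of the scatter.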

Compound 4, half-maximal inhibitory concentration: 49900 nM
Estimate against measurement, compound 4: 2.5-fold (0.40 log units) below; the range from low to high includes it.
By their numbers in this assay, from the lowest: compound 1; then compounds 4, 2 and 3 (each within the scatter of the next).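

Taking the bromo group off the aromatic carbon ortho to a 4-(1H-imidazol-1-yl)butoxy group gives a 4.2-fold higher number from compound 1 to compound 4 (0.62 log units; beyond the scatter) in this assay and provides the first single-place reading in this series. The loss of one heavy atom at this position, meta to a large group, is therefore enough to produce a step beyond the scatter, with the direction favouring the bromo compound. Nothing available on these compounds explains the step.

Going by these compounds, whether this position favours bromine alone or would also accept chloro, methyl or a nitrile on the same aromatic carbon remains open. On these data alone, it is also open whether the step would persist with a shorter or longer chain in place of the butoxy linker, or with an amine in place of the imidazole.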